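Ring swap at the thiocarbonyl: compound 3 to compound 4

This account rests on a few compounds, and the source may have more. Where it says the series, first, only, none or still open, it means among the compounds named here.

Measured so far, in a functional assay on HeLa cells (Homo sapiens) for cytotoxicity, read by MTT assay, with a stated time of 72 h, tested at 100 uM; a lower number here means less inhibition of growth, a higher number more inhibition of growth at the concentration tested:
- compound 1, `N/C(=N\NC(=S)N1CCOCC1)c1ccccn1`, gives 87.2%
- compound 2, `Cc1ccnc(/C(N)=N/NC(=S)N2CCOCC2)c1`, gives 82.7%
- compound 3, `Cc1cccc(/C(N)=N/NC(=S)N2CCOCC2)n1`, gives 82.4%

All three compounds share one core and differ only by a methyl group on an aromatic carbon. The two steps that carry this methyl, a number 4.5 percentage points lower from compound 1 to compound 2 (within the scatter) and a number 4.8 percentage points lower from compound 1 to compound 3 (within the scatter), both stay inside the scatter, so the three numbers are best read as one level rather than as a ranking. Compound 3 and compound 2 show almost the same value, and compound 3 sits at the same level as compound 1 once the scatter is taken into account.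

Compound 4, `Cc1cccc(/C(N)=N/NC(=S)N2CCCC2)n1`, is not yet measured. Its difference from compound 3 is pyrrolidin-1-yl in place of morpholin-4-yl on a thiocarbonyl carbon. Among the compounds with values here, none of the measured steps changes this part of the molecule; they only bear witness that a small change elsewhere, the methyl, left this assay unmoved. Within the data shown here, there is therefore no measured step that speaks directly for or against the ring swap, and no direction can be read from the data.

On that basis compound 4 is expected to stay near compound 3, with an estimated step of a number 1.4 percentage points lower from compound 3 to compound 4 (within the scatter) that lies within the scatter. The estimate for compound 4 in this assay is 81%, with a range from 68% to 92%.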

Compound 4, percent growth inhibition at one concentration: 80.1%
For compound 4 the middle estimate is 0.9 percentage points above the measured one; the range from low to high includes it.
By their numbers in this assay, from the lowest: compounds 4, 3, 2 and 1 (each within the scatter of the next).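

Within the data shown here, until now only a methyl group on an aromatic carbon had varied, so this pair is the first test of the ring on the thiocarbonyl carbon. In this assay, pyrrolidin-1-yl in place of morpholin-4-yl comes with a number 2.3 percentage points lower from compound 3 to compound 4 (within the scatter), so the two compounds read as one level, and for this pair neither the ring oxygen nor the six-membered ring size is needed to keep growth inhibition at that level at the concentration tested. Nothing measured here explains why the swap leaves the number inside the scatter.

Going by these compounds, it remains open whether this tolerance extends to other groups on the thiocarbonyl carbon, such as an open-chain dimethylamino group or a piperazine ring carrying a methyl group on its second nitrogen. All four compounds also sit at one level at a single concentration, so a reading at lower concentrations, where a full dose-response curve could separate them, might still reveal differences that this one number cannot show.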